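The source may report more compounds than this note shows. Statements on the series, on what has been measured and on what is new or still open speak of the compounds shown alone.

Working notes on the series. In a functional assay on A-375 cells (Homo sapiens) for cytotoxicity, read by MTT assay, with a stated time of 72 h (a lower number here means a stronger inhibitor, a higher number a weaker inhibitor), compound 1 `CC1(C)OCC(Cn2cc(Cn3c4c(c5ccccc53)C(=O)c3c[n+]([O-])c5ccccc5c3C4=O)nn2)O1` gives 330 nM, and compound 2 `CCCCN1CCN(CCCCn2c3c(c4ccccc42)C(=O)c2c[n+]([O-])c4ccccc4c2C3=O)CC1` gives 2150 nM. Going by the values given here, compound 2 thus stands at the highest of the two numbers known, with compound 1 the nearer and lower one, a gap beyond the scatter. Compound 3 `O=C1c2c[n+]([O-])c3ccccc3c2C(=O)c2c1c1ccccc1n2CCCN1CCC(O)CC1` is the unmeasured member, differing from compound 2 as 4-hydroxypiperidin-1-yl in place of (4-butylpiperazin-1-yl)methyl on a saturated chain carbon, three bonds along the chain from an aromatic nitrogen. Among the compounds with values here, no measured pair shows this change; the step of a 1.4-fold lower number from compound 2 to compound 3 (0.16 log units; within the scatter) is expected to be small, a modest move to a lower number that may not clear the scatter. For compound 3 an estimate of 1500 nM is taken, with a range from 500 nM to 4500 nM.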

Compound 3, half-maximal inhibitory concentration: 240 nM
The estimate for compound 3 lay 6.3-fold (0.80 log units) above the measured number; measured number outside the range, below it.
By their numbers in this assay, from the lowest: compounds 3 and 1 (each within the scatter of the next); then compound 2.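

In this assay, going by these compounds alone, 4-hydroxypiperidin-1-yl in place of (4-butylpiperazin-1-yl)methyl gives a 9.0-fold lower number from compound 2 to compound 3 (0.95 log units; beyond the scatter), the first step that can be read. The number at this saturated chain carbon, three bonds along the chain from an aromatic nitrogen, therefore depends on the group carried there. Nothing at hand accounts for the size of this step.

The whole group changes at once, so the step cannot be assigned to the ring, the hydroxyl or the butyl group. As far as these compounds go, whether piperidin-1-yl, morpholin-4-yl or 4-methylpiperazin-1-yl at this place would give a similar number remains open.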